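A few compounds are considered here, and "the series" means these few. Any claim that something is new, unique, unknown or untested is made for them only; others in the source may bear on it.

Measured compounds:
- compound 1 `O=C(CN1CCCCC1)N1N=C(c2ccc(F)cc2)CC1c1cc(Cl)ccc1O`: in an assay on isolated protein for inhibition of Amine oxidase [flavin-containing] A (Homo sapiens), read by fluorescence, with stated times of 15 min and 20 min (a higher number here means a weaker inhibitor, a lower number a stronger inhibitor), compound 1 gives 3720 nM
- compound 2 `O=C(CN1CCCCC1)N1N=C(c2ccc(Cl)cc2)CC1c1cc(Cl)ccc1O`: in this assay compound 2 gives 6010 nM

Compound 1 holds the lower of the two numbers, with compound 2 nearest; the step of a 1.6-fold higher number from compound 1 to compound 2 (0.21 log units; within the scatter) is a swap of one halogen for another on an aromatic carbon and lies within the scatter, so the two compounds are not separated.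

Compound 3 `O=C(CN1CCNCC1)N1N=C(c2ccc(F)cc2)CC1c1cc(Cl)ccc1O` is not yet measured. It differs from compound 1 in one place: piperazin-1-yl in place of piperidin-1-yl on a saturated chain carbon bound to a carbonyl carbon.

Among the compounds with values here, no measured step touches this part of the structure; the only step in hand, a 1.6-fold higher number from compound 1 to compound 2 (0.21 log units; within the scatter), concerns a halogen on an aromatic ring and gives no guidance on the piperidin-1-yl to piperazin-1-yl exchange. The expectation is therefore centred on the value of compound 1 with a wide range. For compound 3 in this assay the estimate is 4500 nM, between 1200 nM and 16000 nM, which means an expected step of a 1.2-fold higher number from compound 1 to compound 3 (0.08 log units; within the scatter).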

Compound 3, half-maximal inhibitory concentration: 2400 nM
The estimate for compound 3 lay 1.9-fold (0.27 log units) above the measured number, within the range that was stated.
By their numbers in this assay, from the lowest: compounds 3, 1 and 2 (each within the scatter of the next, the first and the last beyond it).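

At this position on a saturated chain carbon bound to a carbonyl carbon, piperazin-1-yl and piperidin-1-yl are not separated in this assay: the exchange gives a 1.6-fold lower number from compound 1 to compound 3 (0.19 log units; within the scatter). Within the data shown here, the second ring nitrogen and its hydrogen-bond donor therefore leave the inhibition within the same range, and this is the first reading at this part of the structure, since the halogen step concerned only an aromatic carbon. No available measurement bears on why this exchange leaves the number so little moved.

Still open, from the compounds shown here alone, is whether larger changes at this ring would separate from compound 1, such as a morpholine ring, a methyl group on the second piperazine nitrogen, or an open-chain dimethylamino group. A longer chain between the carbonyl and the ring is equally unresolved.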